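Indane amides as MTP inhibitors: nitrogen substituent step

The source may report more compounds than this note shows. Statements on the series, on what has been measured and on what is new or still open speak of the compounds shown alone.

Measured so far:
- compound 1, `Cc1ccc(-c2c(C)cccc2C(=O)Nc2ccc3c(c2)CC(NS(=O)(=O)c2ccccc2)C3)cc1`, 93 nM
- compound 2, `CC(=O)NC1Cc2ccc(NC(=O)c3ccccc3-c3ccc(C(F)(F)F)cc3)cc2C1`, 80 nM

In an assay on isolated protein for inhibition of microsomal triglyceride transfer protein large subunit (Homo sapiens) (on this read-out lower numbers stand for stronger inhibition and higher numbers for weaker inhibition), compound 2 gives 80 nM, the lower of the two numbers; compound 1 gives 93 nM, a gap that lies within the scatter, so the two compounds stand level. Both carry a substituted nitrogen on the saturated ring carbon of the shared core, a sulfonamide in compound 1 and an acetamide in compound 2, without a difference in this assay beyond the scatter.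

Compound 3, `O=C(Nc1ccc2c(c1)CC(NCc1ccccc1)C2)c1ccccc1-c1ccc(C(F)(F)F)cc1`, is not yet measured. It differs from compound 2 as benzyl in place of acetyl on an amine nitrogen. Going by the values given here, with only two measured compounds and no step between them, the size of this change cannot be read from the data. The expected step is a 1.9-fold higher number from compound 2 to compound 3 (0.27 log units; within the scatter), a modest move toward a higher number, not clearly beyond the scatter. Compound 3 is estimated at 150 nM, with a range from 40 nM to 600 nM.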

Compound 3, half-maximal inhibitory concentration: 4800 nM
The estimate for compound 3 lay 32-fold (1.51 log units) below the measured number, outside the stated range (above it).
By their numbers in this assay, from the lowest: compounds 2 and 1 (each within the scatter of the next); then compound 3.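

In this assay the amine nitrogen on the saturated ring carbon proves sensitive to its substituent: benzyl in place of acetyl gives a 60-fold higher number from compound 2 to compound 3 (1.78 log units; beyond the scatter) and marks this as a position where the choice of group matters. The change, acetamido to benzylamino, removes a carbonyl with one hydrogen-bond acceptor and brings in a six-membered aromatic ring with no acceptor, and this single step cannot separate the loss of the one from the entry of the other. Nothing available accounts for the size of the step.

Open, as far as these compounds go, is whether a benzoyl group, which keeps both the carbonyl and the aromatic ring, stays near compound 2 at 80 nM or whether a small alkyl group such as methyl on the amine falls closer to compound 3. Also open, from the compounds shown here alone, is how a urea on the same nitrogen would read.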